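Nitro for trifluoromethyl on a glycosylated oxadiazole scaffold

A few compounds are considered here, and "the series" means these few. Any claim that something is new, unique, unknown or untested is made for them only; others in the source may bear on it.

Of the compounds shown here, three of one series have been measured in an ADME assay on RAW264.7 cells (Mus musculus) for cytotoxicity, read by MTT assay, with a stated time of 48 h; a higher number here means that more compound is tolerated, a lower number that less compound is tolerated. Compound 1 `CC(=O)OC[C@H]1O[C@H](OC[C@@H](Cn2cc(CN(c3nc(-c4ccccc4)no3)C3CCCCC3)nn2)OC(C)=O)C=C[C@@H]1OC(C)=O` gives 28.6 ug/mL in this assay. Compound 2 `C#CCN(c1nc(-c2cccc([N+](=O)[O-])c2)no1)C1CCCCC1` is a smaller analogue that lacks the sugar-bearing triazole arm; in this assay compound 2 gives 34.2 ug/mL. Among the measured compounds shown here, compound 3 `CC(=O)OC[C@H]1O[C@H](OC[C@@H](Cn2cc(CN(c3nc(-c4ccc(C(F)(F)F)cc4)no3)C3CCCCC3)nn2)OC(C)=O)C=C[C@@H]1OC(C)=O` gives 64.1 ug/mL, the highest of the three numbers; its gap to compound 2 lies within the scatter, whereas the single step available, a 2.2-fold higher number from compound 1 to compound 3 (0.35 log units; beyond the scatter), lies beyond it.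

Compound 4 `CC(=O)OC[C@H]1O[C@H](OC[C@@H](Cn2cc(CN(c3nc(-c4ccc([N+](=O)[O-])cc4)no3)C3CCCCC3)nn2)OC(C)=O)C=C[C@@H]1OC(C)=O` is not yet measured. It differs from compound 3 by nitro in place of trifluoromethyl on an aromatic carbon. For the measured compounds named here, no measured step concerns a nitro group entering or a trifluoromethyl group leaving, so the one step known, from hydrogen to trifluoromethyl, does not speak directly to this change. Going by the values given here, the only guidance is that compound 2, which also carries a nitro group, sits within the scatter of compound 3 in this assay. The expectation is therefore a step of no clear direction, with at most a modest drop toward the values of compound 1 and compound 2: the estimated step is a 1.5-fold lower number from compound 3 to compound 4 (0.18 log units; within the scatter). Compound 4 is expected to give about 42 ug/mL in this assay, with a plausible range from 20 ug/mL to 85 ug/mL.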

Compound 4, half-maximal cytotoxic concentration: 64.1 ug/mL
Estimate against measurement, compound 4: 1.5-fold (0.18 log units) below, and the stated range covers the measured number.
By their numbers in this assay, from the lowest: compounds 1, 2, 3 and 4 (each within the scatter of the next, the first and the last beyond it).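

In this assay, nitro in place of trifluoromethyl on the aromatic carbon para to a large group gives no change at the digits printed from compound 3 to compound 4 (within the scatter), so this read-out does not separate the two groups at this position, although only nitro brings hydrogen-bond acceptors. Against hydrogen at the same carbon, nitro gives a 2.2-fold higher number from compound 1 to compound 4 (0.35 log units; beyond the scatter), which matches a 2.2-fold higher number from compound 1 to compound 3 (0.35 log units; beyond the scatter) and shows that, among these three compounds, the step from hydrogen is not confined to trifluoromethyl. Nothing measured here bears on why the two groups give the same number.

As far as these compounds go, it remains open whether a group of another kind at this carbon, such as an amine or a carboxylic acid, would keep the number of compound 4 or fall back toward that of compound 1. Compound 2 differs from these compounds in more than one place, so the compounds shown also leave open whether moving the nitro group to another carbon of this ring would matter when the sugar-bearing triazole arm is present.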